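A few compounds are considered here, and "the series" means these few. Any claim that something is new, unique, unknown or untested is made for them only; others in the source may bear on it.

Values so far in an ADME assay on cells (Hepatocyte, Mus musculus) for cytotoxicity, read by MTT assay, with a stated time of 24 h; on this read-out lower numbers stand for higher toxicity in this test and higher numbers for lower toxicity in this test
compound 1 (`FC(F)(F)c1ccc(-c2nn(-c3ccccc3)cc2-c2nc3ccccc3[nH]2)cc1`) at 159000 nM
compound 2 (`O=S(=O)(c1ccc(F)cc1)n1c(-c2cn(-c3ccccc3)nc2-c2ccc(F)cc2)nc2ccccc21`) at 174000 nM
compound 3 (`O=[N+]([O-])c1ccc(S(=O)(=O)n2c(-c3cn(-c4ccccc4)nc3-c3ccc(C(F)(F)F)cc3)nc3ccccc32)cc1`) at 178000 nM

Compound 3 stands level with compound 1 and compound 2, and all three values lie within the scatter of one another. Compound 4 (`O=S(=O)(c1ccc(F)cc1)n1c(-c2cn(-c3ccccc3)nc2-c2ccc(C(F)(F)F)cc2)nc2ccccc21`) follows from compound 3 by a single change (fluoro in place of nitro on an aromatic carbon): fluoro in place of nitro on an aromatic carbon, para to a large group, which turns (4-nitrophenyl)sulfonyl into (4-fluorophenyl)sulfonyl.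

For the measured compounds named here, no measured pair makes this exchange directly. The closest measured step is a 1.1-fold higher number from compound 1 to compound 3 (0.05 log units; within the scatter) where (4-nitrophenyl)sulfonyl replaces hydrogen on an aromatic nitrogen. That step adds the whole sulfonyl group and stays within the scatter. Compound 2 already carries (4-fluorophenyl)sulfonyl and gives 174000 nM within the scatter of compound 3, although it differs from compound 4 elsewhere in the structure.

On this evidence, no step beyond the scatter is expected in either direction in this assay for this exchange. The expected change is a 1.0-fold lower number from compound 3 to compound 4 (0.02 log units; within the scatter) and so stays within the scatter. Compound 4 is estimated at 170000 nM with an expected range from 105000 nM to 275000 nM in this test.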

Compound 4, half-maximal cytotoxic concentration: 83300 nM
Estimate against measurement, compound 4: 2.0-fold (0.31 log units) above; measured number below the stated range.
By their numbers in this assay, from the lowest: compounds 4, 1, 2 and 3 (each within the scatter of the next, the first and the last beyond it).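

In this assay, for the compounds shown here, the aromatic carbon para to a large group on the sulfonyl-bound ring responds to substitution: fluoro in place of nitro gives a 2.1-fold lower number from compound 3 to compound 4 (0.33 log units; beyond the scatter), a modest step and the first single change to lie beyond the scatter. The step of similar size for trifluoromethyl in place of fluoro on an aromatic carbon, a 2.1-fold lower number from compound 2 to compound 4 (0.32 log units; beyond the scatter), shows that compound 4 separates from both of these close analogues, so the earlier agreement between compound 2 and compound 3 does not mean that these substituents are interchangeable. Against the compound without a sulfonyl group, adding (4-fluorophenyl)sulfonyl gives a 1.9-fold lower number from compound 1 to compound 4 (0.28 log units; within the scatter), which stays within the scatter, as does a 1.1-fold higher number from compound 1 to compound 3 (0.05 log units; within the scatter), so adding either sulfonyl group produces no step beyond the scatter in this assay.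

Open questions are whether an amine or a carboxylic acid at this aromatic carbon would track with compound 3 or with compound 4, and whether nitro paired with fluoro in place of trifluoromethyl elsewhere would leave the value within the scatter of compound 2. Nothing available accounts for the steps out to compound 4.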